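Fluoro Substitution on an Inactive Thiophene Acrylamide

This account rests on a few compounds, and the source may have more. Where it says the series, first, only, none or still open, it means among the compounds named here.

Measured compounds:
Compound 1, `C/C(=C\c1cc(C2=CCCC2)co1)C(N)=O`: in a functional assay on HO8910 cells (Homo sapiens) for cytotoxicity, read by CCK-8 assay, with a stated time of 24 h (on this read-out lower numbers stand for stronger inhibition and higher numbers for weaker inhibition), compound 1 gives > 50000 nM, a limit of the assay.
Compound 2, `C/C(=C\c1cc(-c2ccccc2)cs1)C(N)=O`: in this assay compound 2 gives > 50000 nM, also a limit of the assay.

Going by the values given here, compound 2 stands with nothing more than a limit to its name in this assay, and the only other value shown, that of compound 1, is a limit of the same kind; both rest at the limit of > 50000 nM in this assay, at which 2 of the 2 values shown sit. Among the compounds with values here, no step between measured compounds can be drawn here, because the limit of > 50000 nM in this assay, at which 2 of the 2 values shown sit, leaves no numbers to compare.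

Compound 3, `C/C(=C\c1cc(-c2ccc(F)cc2)cs1)C(N)=O`, has not yet been measured in this assay. It differs from compound 2 by fluoro in place of hydrogen on an aromatic carbon. Given that compound 2 gives > 50000 nM as a limit, there is no measured step on which to build; the expected change is therefore none beyond the scatter, and compound 3 is estimated to move by a step that the limit leaves unreadable from compound 2 to compound 3. Compound 3 is accordingly expected to give about 60000 nM in this assay, within a range of 20000 nM to 200000 nM, most likely reported again as a limit.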

Compound 3, half-maximal inhibitory concentration: > 50000 nM
Compound 3 ended at the assay's limit; the forecaster's own chance of this, stated with the estimate: 80%; the middle value is on the limit's open side.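

Going by these compounds alone, compound 2 and compound 3 both rest at a limit of this assay, so the change from hydrogen to fluoro between them yields no step that can be read: the limit of > 50000 nM in this assay, at which 3 of the 3 values shown sit.

The compounds shown leave open whether any change to the shared core would bring a measurable value in this assay at all.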